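Pyridyl-phenyl propylguanidines: bromo in place of hydrogen

A few compounds are considered here, and "the series" means these few. Any claim that something is new, unique, unknown or untested is made for them only; others in the source may bear on it.

Measured so far:
compound 1 `N=C(NCCCc1c[nH]cn1)NCCC(c1ccccc1)c1ccccn1`: 97.7 nM
compound 2 `COc1ccc(C(CC/N=C(\N)NCCCc2c[nH]cn2)c2ccccn2)cc1`: 269 nM

In a functional assay on ileum for antagonist activity at histamine H1 receptor (Cavia porcellus) (a higher number here means weaker binding, a lower number tighter binding), compound 1 gives 97.7 nM, the lower of the two numbers; compound 2 gives 269 nM, a higher number that lies beyond the scatter. Compound 3 `N=C(NCCCc1c[nH]cn1)NCCC(c1ccc(Br)cc1)c1ccccn1` differs from compound 1 by bromo in place of hydrogen on an aromatic carbon, para to a large group. Among the measured compounds shown here, no measured pair covers this exact change; the only comparison at hand, compound 2 against compound 1, shows a higher number once the phenyl ring carries a group. A modest rise is therefore expected, a 1.6-fold higher number from compound 1 to compound 3 (0.21 log units; within the scatter), near the edge of the scatter. For compound 3 in this assay the estimate is 160 nM, with a range from 60 nM to 450 nM.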

Compound 3, dissociation constant: 120 nM
The estimate for compound 3 lay 1.3-fold (0.12 log units) above the measured number; the range from low to high includes it.
By their numbers in this assay, from the lowest: compounds 1 and 3 (each within the scatter of the next); then compound 2.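

Measured in this assay the change from phenyl to 4-bromophenyl gives a 1.2-fold higher number from compound 1 to compound 3 (0.09 log units; within the scatter) and shows that a group on this aromatic carbon, para to a large group, need not move the number beyond the scatter. Compound 2 alone left open a reading in which any group on the phenyl ring raises the number, and bromo does not fit that reading. Nothing at hand accounts for this result.

Going by these compounds, whether an amine, a carboxylic acid or a methyl group at the same place would also stay within the scatter of compound 1 remains open.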